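Replacing the aminoethyl side chain of compound 3

The source may hold more compounds than are shown below. What is called first, only, known or untested is meant among the compounds shown, and "the series" means these compounds.

In a functional assay on PC-3 cells (Homo sapiens), read by MTT assay, with a stated time of 48 h (on this read-out higher numbers stand for weaker inhibition and lower numbers for stronger inhibition), three compounds built on a shared core have been measured. Compound 1 `CCn1c(C(=O)NCCCN(C)C)ccc1C(CC)(CC)c1ccc(OCC(=O)C(C)(C)C)c(C)c1` gives 1600 nM, compound 2 `CCn1c(C(=O)NCCN)ccc1C(CC)(CC)c1ccc(OCC(=O)C(C)(C)C)c(C)c1` gives 480 nM, and compound 3 `CCn1c(C(=O)NCCN)ccc1C(CC)(CC)c1ccc(OCC(O)C(C)(C)C)c(C)c1` gives 940 nM. Compound 3 thus lies within the usual scatter of both others, and the change leading to it was a 2.0-fold higher number from compound 2 to compound 3 (0.29 log units; within the scatter). Compound 4 `CCn1c(C(=O)N(C)CC(=O)O)ccc1C(CC)(CC)c1ccc(OCC(O)C(C)(C)C)c(C)c1` keeps that part of compound 3 and alters the amide side chain: (carboxymethyl)(methyl)amino in place of (2-aminoethyl)amino on a carbonyl carbon. In words, this puts (carboxymethyl)(methyl)amino in place of (2-aminoethyl)amino on a carbonyl carbon. Among the measured compounds shown here, only one measured step touches this side chain, a 3.3-fold lower number from compound 1 to compound 2 (0.52 log units; beyond the scatter), and it exchanges one amino group for another. For the measured compounds named here, no measured compound carries a carboxymethyl group, so the direction is a judgement and the uncertainty is wide. A change of similar size, towards weaker inhibition, is expected in this assay, and the estimate is a 2.7-fold higher number from compound 3 to compound 4 (0.42 log units; beyond the scatter). For compound 4 the expected value is 2500 nM, with an estimated range of 500 nM to 12000 nM.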

Compound 4, half-maximal inhibitory concentration: 23900 nM
Compound 4: middle estimate off by 9.6-fold (0.98 log units), on the low side, outside the stated range (above it).
By their numbers in this assay, from the lowest: compounds 2, 3 and 1 (each within the scatter of the next, the first and the last beyond it); then compound 4.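

In this assay, among the compounds shown here, the amide side chain proves far less tolerant than the earlier compounds suggested: a 25-fold higher number from compound 3 to compound 4 (1.41 log units; beyond the scatter), whereas exchanging one amine-bearing chain for another gave only a 3.3-fold lower number from compound 1 to compound 2 (0.52 log units; beyond the scatter). For the compounds shown here, compounds 1, 2 and 3 all carry an amine at the end of this chain, so they showed only how much that chain can vary while the amine stays; compound 4, with its carboxylic acid and no amine, is the first to show how much activity can be lost at this position. Nothing shown here gives a reason for the size of this step.

On these data alone, compound 4 removes the amine, adds the carboxylic acid and replaces the amide hydrogen with a methyl in one change, so the contribution of each stays open. A chain ending in a methyl ester, or a carboxymethyl chain that keeps the amide hydrogen, would help separate them.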